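A few compounds are considered here, and "the series" means these few. Any claim that something is new, unique, unknown or untested is made for them only; others in the source may bear on it.

Working notes on the series in a functional assay on PC-3 cells (Homo sapiens) for antiproliferative activity, read by WST assay, with a stated time of 72 h; on this read-out lower numbers stand for an effect already at smaller amounts and higher numbers for an effect only at larger amounts of compound. Compound 1 `CCCCCCCC/C=C\c1c(C)c(/C=C\CCCCCCCC)c2[n+](c1C)CCC2` gives 1.1 uM, and compound 2 `CCCCCCCCCCc1c(C)cc2[n+](c1C)CCC2` gives 1.5 uM, within the scatter of compound 1. Compound 3 `CCCCCCCC/C=C\c1c(C)cc(C)[n+]2c1CCC2` gives 0.2 uM, so compound 1 stands among the higher numbers. Compound 4 `CCCCCCCC/C=C\c1c(C)c(/C=C/CCCCCCCC)c2[n+](c1C)CCC2` is the next case: the two compounds have the same atoms and bonds and differ only in configuration as drawn: 1 of 2 stereo elements differ; a double bond is drawn Z in compound 1 and E in compound 4. Among the measured compounds shown here, no pair differing only in configuration has been measured. For the measured compounds named here, the one measured step, a 5.5-fold lower number from compound 1 to compound 3 (0.74 log units; beyond the scatter), puts hydrogen in place of dec-1-en-1-yl on an aromatic carbon, a different kind of change, so it bears only loosely here and sets no direction. The expected step in this assay is a 1.1-fold lower number from compound 1 to compound 4 (0.04 log units; within the scatter), none beyond the scatter. For compound 4 the estimate is 1 uM, with an expected range of 0.4 uM to 2.5 uM.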

Compound 4, concentration for half-maximal effect: 0.5 uM
The estimate for compound 4 lay 2.0-fold (0.30 log units) above the measured number, within the range that was stated.
By their numbers in this assay, from the lowest: compound 3; then compound 4; then compounds 1 and 2 (each within the scatter of the next).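

In this assay, configuration alone moves the number: a 2.2-fold lower number from compound 1 to compound 4 (0.34 log units; beyond the scatter). The earlier step exchanged hydrogen for dec-1-en-1-yl, whereas here nothing enters or leaves, so double bond geometry matters in this series even with the substituents unchanged. The step can be tied to that one double bond because nothing else separates the pair: the fact that compounds 1 and 4 differ only in the configuration as drawn.

From the compounds shown here alone, whether drawing the remaining Z double bond as E would shift the number in the same direction stays open. Also open, going by these compounds, is how a longer chain, or an amine on the chain, would behave in place of dec-1-en-1-yl.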